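Cyclopropyl in place of cyclohexyl: expectation for compound 4

The compounds below may be only part of what the source reports. "The series", "measured", "known", "first", "only" and "open" are said of these compounds alone.

Measured compounds:
compound 1 `CC#C[C@@H](Cc1nnn[nH]1)c1ccc(OCc2ccc3sc(F)c(-c4ccccc4C)c3c2)cc1` – 14 nM
compound 2 `CC#C[C@@H](Cc1nnn[nH]1)c1ccc(OCc2ccc3scc(-c4cc(OCCOC)ccc4C)c3c2)cc1` – 26 nM
compound 3 `CC#C[C@@H](Cc1nnn[nH]1)c1ccc(OCc2ccc3scc(C4CCCCC4)c3c2)cc1` – 16 nM

In a functional assay on cells for agonist activity at Free fatty acid receptor 1 (Rattus norvegicus), read by FLIPR and calcium flux (on this read-out higher numbers stand for an effect only at larger amounts of compound and lower numbers for an effect already at smaller amounts), compound 3 gives 16 nM, the second highest of the three numbers; compound 1 lies nearest and compound 2 furthest, and all three numbers sit within the scatter of one another, so no order can be read among them.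

Compound 4 `CC#C[C@@H](Cc1nnn[nH]1)c1ccc(OCc2ccc3scc(C4CC4)c3c2)cc1` has not been measured. It differs from compound 3 by cyclopropyl in place of cyclohexyl on an aromatic carbon. Among the measured compounds shown here, the only measured step at this place is a 1.6-fold lower number from compound 2 to compound 3 (0.21 log units; within the scatter), where a substituted phenyl gave way to cyclohexyl without a change beyond the scatter. For the measured compounds named here, no measured step compares two rings of different size at this place, so the change from cyclohexyl to cyclopropyl has no direct precedent. Given the insensitivity of this position to the earlier exchange, no step beyond the scatter is expected, with a wider range to allow for the smaller ring. Compound 4 is therefore expected at 22 nM, within 7 nM to 70 nM. The expected step is a 1.4-fold higher number from compound 3 to compound 4 (0.14 log units; within the scatter).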

Compound 4, half-maximal effective concentration: 239 nM
The estimate for compound 4 lay 11-fold (1.04 log units) below the measured number; measured number outside the range, above it.
By their numbers in this assay, from the lowest: compounds 1, 3 and 2 (each within the scatter of the next); then compound 4.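

In this assay the step of a 15-fold higher number from compound 3 to compound 4 (1.17 log units; beyond the scatter) shows that this position, on an aromatic carbon two ring bonds from the ring sulfur, is not indifferent to the group it carries. Cyclopropyl also stands apart from the substituted phenyl in the step of a 9.2-fold higher number from compound 2 to compound 4 (0.96 log units; beyond the scatter) and so from both larger groups, whereas the earlier step of a 1.6-fold lower number from compound 2 to compound 3 (0.21 log units; within the scatter) had shown only that cyclohexyl and that phenyl could not be told apart. No measurement on hand accounts for this rise in the number.

Going by these compounds, how the number runs between the three-membered and six-membered rings remains open, for instance with cyclobutyl or cyclopentyl. Also open, on these data alone, is whether an open chain such as isopropyl or n-hexyl would read like cyclohexyl or like cyclopropyl at this place.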